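The source may report more compounds than this note shows. Statements on the series, on what has been measured and on what is new or still open speak of the compounds shown alone.

In a functional assay on MCF7 cells (Homo sapiens) for inhibition, read by MTT assay (a higher number here means a weaker inhibitor of growth, a lower number a stronger inhibitor of growth), compound 1 `COc1cc2oc(-c3cccc(NC(=O)c4ccccc4)c3)cc(=O)c2c(OC)c1OC` gives 12100 nM and compound 2 `COc1cc2oc(-c3cccc(NC(=O)c4ccc(Br)cc4)c3)cc(=O)c2c(OC)c1OC` gives 9650 nM while compound 3 `COc1cccc(C(=O)Nc2cccc(-c3cc(=O)c4c(OC)c(OC)c(OC)cc4o3)c2)c1` gives 7670 nM on the same scale. All three numbers lie within the usual scatter of one another, so compound 3 stands level with the other two.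

Compound 4 `COc1ccccc1C(=O)Nc1cccc(-c2cc(=O)c3c(OC)c(OC)c(OC)cc3o2)c1` has 2-methoxyphenyl in place of the 3-methoxyphenyl of compound 3 on a carbonyl carbon, and 2-methoxyphenyl in place of 3-methoxyphenyl on a carbonyl carbon sums up that change.

Among the compounds with values here, two measured steps bear on it. Methoxy in place of hydrogen gave a 1.6-fold lower number from compound 1 to compound 3 (0.20 log units; within the scatter) as its step, and 3-methoxyphenyl in place of 4-bromophenyl gave a 1.3-fold lower number from compound 2 to compound 3 (0.10 log units; within the scatter) as its step, both within the scatter. Within the data shown here, no measured compound carries 2-methoxyphenyl, so its own effect remains unknown.

A step within the scatter is therefore expected in this assay with no firm direction. The expected size is a 1.2-fold higher number from compound 3 to compound 4 (0.07 log units; within the scatter) and this stays within the scatter. Compound 4 is estimated at 9000 nM with an expected range from 4000 nM to 20000 nM across repeat measurements.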

Compound 4, concentration for 50% growth inhibition: 15300 nM
Beside the measured number, compound 4's estimate is 1.7-fold (0.23 log units) below it; the range from low to high includes it.
By their numbers in this assay, from the lowest: compounds 3, 2, 1 and 4 (each within the scatter of the next).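

In this assay, 2-methoxyphenyl in place of 3-methoxyphenyl on the carbonyl carbon gives a 2.0-fold higher number from compound 3 to compound 4 (0.30 log units; within the scatter), so this change of the methoxy group's place on the ring does not carry the number beyond the scatter. The other two comparisons, a 1.6-fold higher number from compound 2 to compound 4 (0.20 log units; within the scatter) and a 1.3-fold higher number from compound 1 to compound 4 (0.10 log units; within the scatter), also stay within the scatter, so phenyl, 4-bromophenyl, 3-methoxyphenyl and 2-methoxyphenyl on this carbonyl carbon cannot be told apart in this assay. No measurement here offers an explanation for how these numbers fall.

The compounds shown leave open whether a different kind of group on this phenyl ring, such as an amine or a carboxylic acid, would give a step beyond the scatter. They also leave open what a longer chain in place of methoxy would do.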